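This account rests on a few compounds, and the source may have more. Where it says the series, first, only, none or still open, it means among the compounds named here.

Working notes on the sulfonyl piperidine series.

Within the data shown here, compound 2 `Cc1cc(C)c(S(=O)(=O)N2CCC(c3ccccc3)CC2)c(C)c1` is one of three compounds measured so far in a functional assay on DLD-1 cells (Homo sapiens) for antiproliferative activity, read by CellTiter-Glo, with a stated time of 72 h; on this read-out higher numbers stand for weaker inhibition and lower numbers for stronger inhibition. Compound 2 reaches only the assay limit, > 5000 nM, so a limit and not a number is known for it; this is the limit of > 5000 nM in this assay, at which 1 of the 3 values shown sits. The two other measured compounds both carry a substituted piperidinyl group on the saturated ring and a biaryl on the sulfonyl side: compound 1 `Cc1ccc(-c2ccccc2S(=O)(=O)N2CCC(N3CCC(C)CC3)CC2)cc1` gives 366 nM in this assay, and compound 3 `Cc1cc(C)cc(-c2cccc(S(=O)(=O)N3CCC(N4CCC(C)CC4)CC3)c2)c1` gives 41 nM.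

Compound 4 `Cc1cc(C)c(S(=O)(=O)N2CCC(N3CCCCC3)CC2)c(C)c1` is not yet measured. It differs from compound 2 in one place, (piperidin-1-yl in place of phenyl on a saturated ring carbon). Among the measured compounds shown here, compound 4 keeps the trimethylphenyl sulfonyl part of compound 2, so no measured pair isolates this change, and the biaryl part of compounds 1 and 3 is absent.

Expected size of step: since compound 2 is a limit, any number for compound 4 at or under that limit would appear as a gain, but the gain is expected to be modest and uncertain; the step from compound 2 to compound 4 is estimated at an at least 1.6-fold lower number from compound 2 to compound 4 (0.22 log units; that floor lies within the scatter). The estimate for compound 4 in this assay is 3000 nM, with a range from 600 nM to 15000 nM, and a substantial chance that only a limit is returned.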

Compound 4, half-maximal inhibitory concentration: 2200 nM
Estimate against measurement, compound 4: 1.4-fold (0.13 log units) above; the measured number falls inside the stated range.
By their numbers in this assay, from the lowest: compound 3; then compound 1; then compound 4. At a limit, above all of these: compound 2.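

With the trimethylphenyl sulfonyl part held constant, this saturated ring carbon, three ring bonds from the ring nitrogen, is shown for the first time to respond to a change of group in this assay: piperidin-1-yl in place of phenyl gives an at least 2.2-fold lower number from compound 2 to compound 4 (0.35 log units; beyond the scatter). The two groups have the same count of heavy atoms, so this one-place change swaps an aromatic carbon ring for a non-aromatic ring with a nitrogen, and compound 4 gives a measured number, 2200 nM, without the biaryl part of compound 1 and compound 3. The true size of the step stays unknown and only its floor can be read, because compound 2 stands at a limit: the limit of > 5000 nM in this assay, at which 1 of the 4 values shown sits.

The compounds shown leave open whether the ring nitrogen itself matters at this carbon, a question that a cyclohexyl group or a morpholine there would address. No pair shown tests whether the same change carries over to a biaryl on the sulfonyl side, or what the methyl group on the piperidine of compound 1 and compound 3 contributes.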